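The compounds below may be only part of what the source reports. "The series", "measured", "known", "first", "only" and "open" are said of these compounds alone.

Compound 1, `Clc1ccc(-c2nc3ncccn3c2NC2CCCCC2)cc1`.
In a toxicity assay on A549 cells (Homo sapiens) for cytotoxicity, read by luminescence and CellTiter-Glo, with a stated time of 48 h (a higher number here means that more compound is tolerated, a lower number that less compound is tolerated), compound 1 gives > 100000 nM, which is a limit of the assay rather than a number.
Compound 2, `c1ccc(-c2nc3ncccn3c2NC2CCCCC2)cc1`.
In this assay compound 2 gives 100000 nM.

Compound 2 thus holds the only plain number shown; the other value is a limit, as the limit of > 100000 nM in this assay, at which 1 of the 2 values shown sits, records. Within the data shown here, the single measured step, a number no higher from compound 1 to compound 2 (the limit leaves the size open), has no readable size. Compound 3, `Oc1cccc(-c2nc3ncccn3c2NC2CCCCC2)c1`, differs from compound 2 by hydroxy in place of hydrogen on an aromatic carbon. Among the measured compounds shown here, with no measured step of known size bearing on this change, compound 3 is expected to sit near compound 2 in this assay, with an estimated step of no change at the digits printed from compound 2 to compound 3 (within the scatter). The estimate for compound 3 is 100000 nM, between 30000 nM and 300000 nM.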

Compound 3, half-maximal cytotoxic concentration: 100000 nM
Compound 3: middle estimate and measured number agree at the digits printed, within the range that was stated.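

In this assay, among these compounds, the change from phenyl to 3-hydroxyphenyl gives the first step of readable size, which reads no change at the digits printed from compound 2 to compound 3 (within the scatter). At this place on the ring, compound 2 and compound 3 cannot be told apart by this read-out. The change from 4-chlorophenyl to 3-hydroxyphenyl reads a number no higher from compound 1 to compound 3 (the limit leaves the size open). Compound 1 carries a limit of the assay rather than a number, so the steps from it cannot be read: the limit of > 100000 nM in this assay, at which 1 of the 3 values shown sits.

The compounds shown leave open whether an amine or a carboxylic acid at this same place would read like hydroxy. They also leave open whether any group at all on this ring gives a step beyond the scatter.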